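Compound 3 and the Carboxyphenyl Change

The source may hold more compounds than are shown below. What is called first, only, known or untested is meant among the compounds shown, and "the series" means these compounds.

Compound 1, `CNc1ccc(C(=O)Oc2cc(O/N=[N+](\[O-])N(C)C)c([N+](=O)[O-])cc2[N+](=O)[O-])cc1`: 6900 nM
Compound 2, `CN(C)/[N+]([O-])=N/Oc1cc(Nc2ccc(C(=O)O)cc2)c([N+](=O)[O-])cc1[N+](=O)[O-]`: 9000 nM

In a functional assay on OVCAR-3 cells (Homo sapiens) for cytotoxicity (a higher number here means a weaker inhibitor of growth, a lower number a stronger inhibitor of growth), compound 2 stands at 9000 nM, and compound 1 at 6900 nM lies within the scatter of it, so the two are not told apart. Compound 3, `CN(C)/[N+]([O-])=N/Oc1cc(Nc2cccc(C(=O)O)c2)c([N+](=O)[O-])cc1[N+](=O)[O-]`, is not yet measured; it differs from compound 2 in one place: 3-carboxyphenyl in place of 4-carboxyphenyl on a nitrogen on an aromatic ring. Going by the values given here, no step between measured compounds gauges this change, so no step beyond the scatter is expected. In this assay compound 3 is expected to give about 9000 nM, within 4000 nM to 20000 nM. The expected step of no change at the digits printed from compound 2 to compound 3 (within the scatter) is thus essentially none.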

Compound 3, concentration for total growth inhibition in the OVCAR-3 assay: 30000 nM
Estimate against measurement, compound 3: 3.3-fold (0.52 log units) below, outside the stated range (above it).
By their numbers in the OVCAR-3 assay, from the lowest: compounds 1 and 2 (each within the scatter of the next); then compound 3.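

With 3-carboxyphenyl in place of 4-carboxyphenyl on a nitrogen on an aromatic ring, the OVCAR-3 assay shows a 3.3-fold higher number from compound 2 to compound 3 (0.52 log units; beyond the scatter) and so a weaker inhibitor of growth, which means that where the carboxylic acid sits on this ring matters even though the two groups have the same atoms. In a physicochemical assay for solubility, in phosphate buffer, at 37 degrees C (a higher number here means a more soluble compound, a lower number a less soluble compound), compound 2 gives > 3000000 nM as a limit of the assay. In the physicochemical assay compound 3 gives > 2000000 nM as a limit too, and the step between the two cannot be read.

Going by these compounds, whether an amide or a methyl ester in place of the carboxylic acid would show the same step stays open. Nothing shown gives a cause for the change in growth inhibition.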